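Ester to acid on a benzofuran-sulfonamide series

The compounds below may be only part of what the source reports. "The series", "measured", "known", "first", "only" and "open" are said of these compounds alone.

Measured compounds:
- compound 1, `CCOC(=O)c1oc2ccc(N(Cc3ccccc3)S(=O)(=O)c3ccc(Br)cc3)cc2c1C`: 8700 nM in a functional assay on HCT-116 cells (Homo sapiens) for inhibition, read by MTT assay, with a stated time of 72 h; a higher number here means a weaker inhibitor, a lower number a stronger inhibitor
- compound 2, `CCOC(=O)c1oc2ccc(N(Cc3ccccc3)S(=O)(=O)c3ccc(C(F)(F)F)cc3)cc2c1C`: 12700 nM in this assay

Going by the values given here, compound 2 holds the higher of the two numbers in this assay, but its only neighbour is compound 1, and the move a 1.5-fold higher number from compound 1 to compound 2 (0.16 log units; within the scatter) stays within the usual scatter, so the two compounds cannot be told apart on these data.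

Compound 3, `Cc1c(C(=O)O)oc2ccc(N(Cc3ccccc3)S(=O)(=O)c3ccc(C(F)(F)F)cc3)cc12`, has not yet been measured. It differs from compound 2 by hydrogen in place of ethyl on an oxygen next to a carbonyl group, that is, an ethoxycarbonyl group becomes a carboxy group. Among the compounds with values here, the one measured step concerns a different part of the molecule, the substituent on the aromatic carbon, and says nothing about the ester. No measured comparison therefore bears on this change, and its direction cannot be read from the numbers at hand.

Compound 3 is expected to show a step of a 1.6-fold higher number from compound 2 to compound 3 (0.20 log units; within the scatter), stated with wide uncertainty. The estimated value for compound 3 is 20000 nM, with a range from 5000 nM to 80000 nM.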

Compound 3, half-maximal inhibitory concentration: 21100 nM
Estimate against measurement, compound 3: 1.1-fold (0.02 log units) below; low and high end bracket the measured number.
By their numbers in this assay, from the lowest: compounds 1, 2 and 3 (each within the scatter of the next, the first and the last beyond it).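

In this assay, going by these compounds alone, the change from ethoxycarbonyl to carboxy gives a 1.7-fold higher number from compound 2 to compound 3 (0.22 log units; within the scatter) and this is the first measured step at this position. The ethyl on this oxygen can therefore be replaced by hydrogen without a reading that stands clear of the scatter, at least while trifluoromethyl is the substituent on the aromatic carbon. Nothing measured here accounts for this result.

Whether the same change would read alike with bromo in place of trifluoromethyl remains an open question. From the compounds shown here alone, it also remains open how other groups at this position would read, such as a primary amide, a nitrile or an ester with a longer chain like butyl.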